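Furan-2-yl in place of a difluorophenyl on the core

The compounds below may be only part of what the source reports. "The series", "measured", "known", "first", "only" and "open" are said of these compounds alone.

Working notes on a small thiazole acetic acid series. Compound 1 `O=C(O)Cc1sc(C(c2ccccc2)c2ccc(F)cc2)nc1-c1ccc(Cl)cc1` gives 36 nM in an in vitro functional assay on HEK285-7 cells for antagonist activity at prostaglandin D2 receptor 2 (Homo sapiens), read by BRET and beta-arrestin recruitment; on this read-out lower numbers stand for stronger inhibition and higher numbers for weaker inhibition; compound 2 `O=C(O)Cc1sc(C(c2ccccc2)c2ccccc2)nc1-c1ccc(F)c(F)c1` gives 43 nM in the same read-out. Compound 3 `O=C(O)Cc1sc(C(c2ccc(F)cc2)c2ccc(F)cc2)nc1-c1cc(F)cc(F)c1` gives 340 nM and stands highest of the three numbers, with its gaps to compound 2 and to compound 1 both beyond the usual scatter, so compound 3 is the weakest inhibitor measured so far.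

The next compound, compound 4 `O=C(O)Cc1sc(C(c2ccc(F)cc2)c2ccc(F)cc2)nc1-c1ccco1`, keeps the bis(4-fluorophenyl)methyl side of compound 3 and changes only the aromatic group on the core: furan-2-yl in place of 3,5-difluorophenyl on an aromatic carbon. Going by the values given here, no single-point step between measured compounds exists for this position, so no measured size of effect can be carried over.

Given that compound 3 sits at 340 nM, compound 4 is expected to stay in the weaker part of the series, with a step of a 1.2-fold higher number from compound 3 to compound 4 (0.07 log units; within the scatter) that may well lie within the scatter. The estimate for compound 4 is 400 nM, with a range from 100 nM to 2000 nM.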

Compound 4, half-maximal inhibitory concentration: 140 nM
For compound 4 the middle estimate is 2.9-fold (0.46 log units) above the measured one; low and high end bracket the measured number.
By their numbers in this assay, from the lowest: compounds 1 and 2 (each within the scatter of the next); then compound 4; then compound 3.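

With the bis(4-fluorophenyl)methyl side held fixed, the step of a 2.4-fold lower number from compound 3 to compound 4 (0.39 log units; beyond the scatter) in this assay gives the series its first measured size of effect for a single-place change, here furan-2-yl in place of 3,5-difluorophenyl. The aromatic group on the core, on the carbon next to the ring nitrogen, therefore affects the read-out, and replacing the six-membered carbon ring with a five-membered aromatic ring with 1 hetero atom does not cost inhibition in this pair, although the step is modest. No measurement at hand bears on the reason for this step.

Thiophen-2-yl or unsubstituted phenyl at this position would help separate the contribution of the furan oxygen from that of ring size. Going by these compounds, it also remains open whether furan-2-yl gives a step of similar size alongside a diphenylmethyl group.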